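The source may report more compounds than this note shows. Statements on the series, on what has been measured and on what is new or still open speak of the compounds shown alone.

Three compounds have been measured so far in a functional assay on K562 cells (Homo sapiens) for cytotoxicity, read by MTT assay, with a stated time of 3 days; a higher number here means a weaker inhibitor, a lower number a stronger inhibitor:

compound 1 `CNc1nc(SCc2nc3ccccc3[nH]2)nc(-c2ccccc2)c1C#N`: 13.2 nM
compound 2 `N#Cc1c(Nc2nccs2)nc(SCc2nc3ccccc3[nH]2)nc1-c1ccccc1`: 14.7 nM
compound 3 `N#Cc1c(-c2ccccc2)nc(SCc2nc3ccccc3[nH]2)nc1N1CCNCC1`: 4.38 nM

Of these, compound 3 stands lowest at 4.38 nM, and its gaps to the other two lie beyond the scatter. Compound 4 `Cc1ccc(S(=O)(=O)N2CCN(c3nc(SCc4nc5ccccc5[nH]4)nc(-c4ccccc4)c3C#N)CC2)cc1` keeps the whole of compound 3 and changes one place: (4-methylphenyl)sulfonyl in place of hydrogen on an amine nitrogen in a ring. In words, this is (4-methylphenyl)sulfonyl in place of hydrogen on an amine nitrogen in a ring.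

Among the compounds with values here, no measured step adds this group, so the evidence is indirect. Two steps bring in the piperazin-1-yl group with its free amine hydrogen: a 3.0-fold lower number from compound 1 to compound 3 (0.48 log units; beyond the scatter) and a 3.4-fold lower number from compound 2 to compound 3 (0.53 log units; beyond the scatter). Both are modest. A third step, a 1.1-fold higher number from compound 1 to compound 2 (0.05 log units; within the scatter), puts 1,3-thiazol-2-yl in place of methyl and stays within the scatter. Taken together, these steps suggest that compound 4 may give back the modest gain seen in a 3.0-fold lower number from compound 1 to compound 3 (0.48 log units; beyond the scatter), and a modest move toward a higher number is expected, not a large one.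

For compound 4 the expected value in this assay is 10 nM. The estimated range for compound 4 runs from 3 nM to 35 nM. The expected change is a 2.3-fold higher number from compound 3 to compound 4 (0.36 log units; beyond the scatter).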

Compound 4, half-maximal inhibitory concentration: 11.3 nM
The estimate for compound 4 lay 1.1-fold (0.05 log units) below the measured number, and the stated range covers the measured number.
By their numbers in this assay, from the lowest: compound 3; then compounds 4, 1 and 2 (each within the scatter of the next).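

In this assay, within the data shown here, the earlier compounds varied only the group on the aromatic carbon, so compound 4 is the first to show a change on the amine nitrogen in the six-membered ring, and that change gives a 2.6-fold higher number from compound 3 to compound 4 (0.41 log units; beyond the scatter). The step is modest even though the entering (4-methylphenyl)sulfonyl brings 10 heavy atoms and one six-membered aromatic ring in place of a single hydrogen, so this nitrogen carries a large group and compound 4 still gives 11.3 nM in this cytotoxicity read-out, which shows that the free amine hydrogen of compound 3 is not needed for a number of this order, though compound 3 remains the lower of the two. Nothing available explains why the number moves in this direction.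

The compounds shown leave open whether a small group on the same nitrogen, such as methyl or acetyl, would stay as close to compound 3 or move further from it. They also leave open which part of the entering group carries the step, a question that methanesulfonyl or benzoyl on that nitrogen would begin to separate.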